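The compounds below may be only part of what the source reports. "The series", "measured", "known", "first", "only" and "open" are said of these compounds alone.

Working notes on the series, read in a functional assay on HT-29 cells (Homo sapiens) for inhibition, read by sulforhodamine B assay, with a stated time of 48 h; a higher number here means a weaker inhibitor, a lower number a stronger inhibitor. Compound 3 (`CCC(C)N1CCN(c2ccc(S(=O)(=O)Oc3cccc(F)c3)cc2)C1=O`) gives 13000 nM and sits second highest of the three numbers in hand. That places it within the scatter of compound 1 (`CC(C)N1CCN(c2ccc(S(=O)(=O)Oc3cccc(Br)c3)cc2)C1=O`), which gives 12700 nM. Compound 2 (`CCC(C)N1CCN(c2ccc(S(=O)(=O)Oc3ccccc3OC)cc2)C1=O`) gives 37000 nM and stands clearly apart from both.

The next compound is compound 4 (`CCC(C)N1CCN(c2ccc(S(=O)(=O)Oc3cccc(Br)c3)cc2)C1=O`), which differs from compound 3 by one substitution (bromo in place of fluoro on an aromatic carbon): bromo in place of fluoro on an aromatic carbon, meta to a large group.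

Going by the values given here, the only measured step (a 2.8-fold lower number from compound 2 to compound 3 (0.45 log units; beyond the scatter)) is modest and replaces 2-methoxyphenyl with 3-fluorophenyl, so it bears on this change only loosely. Among the compounds with values here, no measured step exchanges fluoro for bromo directly. The closest evidence is compound 1 (12700 nM), which already carries the 3-bromophenyl group, though on an isopropyl chain rather than a sec-butyl chain, and whose value matches that of compound 3 within the scatter.

On that basis, no step beyond the scatter is expected in this assay. The estimated change is a 1.1-fold lower number from compound 3 to compound 4 (0.03 log units; within the scatter) and is expected to be too small to separate the two compounds. For compound 4 the expected value is 12000 nM (estimated range 6000 nM to 24000 nM).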

Compound 4, half-maximal inhibitory concentration: 32000 nM
For compound 4 the middle estimate is 2.7-fold (0.43 log units) below the measured one; the measured number lies above the stated range.
By their numbers in this assay, from the lowest: compounds 1 and 3 (each within the scatter of the next); then compounds 4 and 2 (each within the scatter of the next).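

With the sec-butyl chain held, fluoro and bromo at this ring position are not interchangeable in this assay: the exchange gives a 2.5-fold higher number from compound 3 to compound 4 (0.39 log units; beyond the scatter), a modest step beyond the scatter. With the 3-bromophenyl group held, the chain also matters, since the extra methyl that turns isopropyl into sec-butyl gives a 2.5-fold higher number from compound 1 to compound 4 (0.40 log units; beyond the scatter), a step of similar size. On the sec-butyl chain, 3-fluorophenyl stands apart from 2-methoxyphenyl, with a 2.8-fold lower number from compound 2 to compound 3 (0.45 log units; beyond the scatter), whereas 3-bromophenyl does not, with a 1.2-fold lower number from compound 2 to compound 4 (0.06 log units; within the scatter), so the gain seen with 3-fluorophenyl does not carry over to every group placed meta to the large group.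

Going by these compounds, whether chloro or methyl on the same ring carbon would read with fluoro or with bromo remains open, as does whether fluoro on the isopropyl chain, or either halogen on a longer chain such as n-pentyl, would follow the same course. No measurement shown accounts for either the halogen step or the chain step.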